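Hydroxy to Hydrogen on the Piperidine Side Chain

The source may report more compounds than this note shows. Statements on the series, on what has been measured and on what is new or still open speak of the compounds shown alone.

Compound 1 `C=CCc1cc(O)c(O)c(CN2CCC(CO)CC2)c1`: 43.3%
Compound 2 `C#CCOc1ccc(CC=C)cc1O`: 34.2%

Of the compounds shown here, two have been measured in a functional assay on HL-60 cells (Homo sapiens) for inhibition, read by MTT assay, with a stated time of 72 h, tested at 50 uM; a higher number here means more inhibition of growth at the concentration tested, a lower number less inhibition of growth. Compound 1 gives 43.3%, and compound 2 gives 34.2%. Compound 1 holds the higher of the two numbers, but the gap to compound 2 lies within the usual scatter of repeated measurements, so the two values show no difference that can be relied on. Within the data shown here, no pair of measured compounds differs in a single place, so no step of known size is available to guide an expectation.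

Compound 3 `C=CCc1cc(O)c(O)c(CN2CCC(C)CC2)c1` has not yet been measured. It differs from compound 1 as follows: hydrogen in place of hydroxy on a saturated chain carbon bound to a saturated ring carbon. The change is small in count, and nothing in the measured values speaks to the effect of this change. In this assay a step from compound 1 to compound 3 of a size no larger than the scatter, in either direction, is expected: a number 3.3 percentage points lower from compound 1 to compound 3 (within the scatter). For compound 3 the estimated value is 40%, in a range from 25% to 55%.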

Compound 3, percent growth inhibition at one concentration: 91.8%
The estimate for compound 3 lay 51.8 percentage points below the measured number, outside the stated range (above it).
By their numbers in this assay, from the lowest: compounds 2 and 1 (each within the scatter of the next); then compound 3.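

In this assay, hydrogen in place of hydroxy on a saturated chain carbon bound to a saturated ring carbon gives a large step, a number a number 48.5 percentage points higher from compound 1 to compound 3 (beyond the scatter) and the first step of known size among these compounds. This place on the piperidine side chain therefore responds strongly in this read-out: the change, which reads hydroxymethyl to methyl when cut one bond further out, removes only one heavy atom, one oxygen, yet the step lies beyond the scatter. Nothing at hand explains how this exchange produces a step of this size.

The compounds shown leave open whether the step follows the loss of the hydroxy group in particular or would also appear with other groups at this place, a question that a methoxymethyl group, an aminomethyl group, a carboxylic acid or a longer alkyl chain such as ethyl or propyl could address. They also leave open whether the same exchange would give a step of similar size on another core, and how compound 3 behaves at concentrations other than the single one tested.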